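This account rests on a few compounds, and the source may have more. Where it says the series, first, only, none or still open, it means among the compounds named here.

Compound 1 `CCC(=O)N1C[C@@H](C(=O)N2CCN(c3ccc(C)cc3[C@@H](NC(=O)CCN(C)C)C(C)C)CC2)[C@H](c2ccc(Cl)cc2)C1` gives 4.6 nM in an assay on HEK293 cells for displacement of a labelled ligand from Melanocortin receptor 4 (Homo sapiens); on this read-out higher numbers stand for weaker inhibition and lower numbers for stronger inhibition.
Compound 2 `CC(C)[C@H](NC(=O)CCN(C)C)c1cccc(F)c1N1CCN(C(=O)[C@@H]2CN(C(C)C)C[C@H]2c2ccc(Cl)cc2)CC1` gives 5.3 nM in this assay.
Compound 3 `Cc1ccc(N2CCN(C(=O)[C@@H]3CNC[C@H]3c3ccc(Cl)cc3)CC2)c([C@@H](NC(=O)CCN(C)C)C(C)C)c1` gives 7.2 nM in this assay.

Among these three numbers compound 2 stands second highest; its nearest neighbour is compound 1, whose number is slightly lower, and its furthest is compound 3, whose number is slightly higher, and both of these gaps lie within the usual scatter of the measurement. The three measured compounds are thus indistinguishable on this read-out.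

The unmeasured compound 4 `CC(C)[C@H](NC(=O)CCN(C)C)c1cccc(F)c1N1CCN(C(=O)[C@@H]2CN(C(C)C)C[C@H]2c2cc(F)ccc2F)CC1` differs from compound 2 in one place: 2,5-difluorophenyl in place of 4-chlorophenyl on a saturated ring carbon. Within the data shown here, the only measured step in the set, a 1.6-fold higher number from compound 1 to compound 3 (0.19 log units; within the scatter), concerns a change on the ring nitrogen, not the aryl group on the saturated ring carbon, so it does not bear on this change. Among the measured compounds shown here, no measured pair shows what swapping one aryl group for another does here. Without such a precedent, a step beyond the scatter in either direction cannot be predicted with confidence, and the expectation for compound 4 is a number near that of compound 2, with a wide allowance. The step expected from compound 2 to compound 4 is a 1.5-fold higher number from compound 2 to compound 4 (0.18 log units; within the scatter). Compound 4 is therefore estimated at 8 nM in this assay, within a range from 2.5 nM to 30 nM.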

Compound 4, inhibition constant: 2050 nM
For compound 4 the middle estimate is 260-fold (2.41 log units) below the measured one; the measured number lies above the stated range.
By their numbers in this assay, from the lowest: compounds 1, 2 and 3 (each within the scatter of the next); then compound 4.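

In this assay, among these compounds, exchanging 4-chlorophenyl for 2,5-difluorophenyl on the saturated ring carbon produces a 390-fold higher number from compound 2 to compound 4 (2.59 log units; beyond the scatter), while the only earlier step, at the ring nitrogen, is a 1.6-fold higher number from compound 1 to compound 3 (0.19 log units; within the scatter). The large step shows that, at least in this pair, binding strength depends heavily on which aryl group sits at this position, even though the two groups look alike by simple counts: each has one six-membered aromatic ring of carbon only, with no hydrogen-bond donors or acceptors and no net charge. Nothing in the data explains why the number rises so sharply.

On these data alone, this single swap removes the chlorine and adds two fluorines at once, so it remains open whether the loss of the chlorine, the arrival of either fluorine, or the combination accounts for the step, and an unsubstituted phenyl group or a 4-bromophenyl group on the same carbon would help to separate these possibilities. As far as these compounds go, it is also open whether the same swap would have a similar effect in compound 1 or compound 3, which carry a propanoyl group and a hydrogen on the ring nitrogen instead of an isopropyl group.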